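A few compounds are considered here, and "the series" means these few. Any claim that something is new, unique, unknown or untested is made for them only; others in the source may bear on it.

Measured in a functional assay on HeLa cells (Homo sapiens) for antiproliferative activity, read by MTT assay, with a stated time of 48 h; on this read-out higher numbers stand for weaker inhibition and lower numbers for stronger inhibition:
- compound 1 `Fc1ccc2[nH]c(-c3cn(-c4ccccc4)nc3-c3ccccc3)nc2c1`: 3610 nM
- compound 2 `Fc1ccc(-c2nn(-c3ccccc3)cc2-c2nc3cc(F)ccc3[nH]2)cc1`: 1570 nM
- compound 3 `Fc1ccc2[nH]c(-c3cn(-c4ccccc4)nc3-c3ccc(Cl)cc3)nc2c1`: 2770 nM

Compound 3, at 2770 nM, lies within the scatter of both other compounds: a 1.3-fold lower number from compound 1 to compound 3 (0.12 log units; within the scatter), and a 1.8-fold higher number from compound 2 to compound 3 (0.25 log units; within the scatter). Next comes compound 4 `COc1ccc(-c2nn(-c3ccccc3)cc2-c2nc3cc(F)ccc3[nH]2)cc1`, with the change methoxy in place of chloro on an aromatic carbon, 4-chlorophenyl to 4-methoxyphenyl.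

For the measured compounds named here, no methoxy compound has been measured, so the only guide is the three compounds that vary at this place. Going by the values given here, only one of their steps goes beyond the scatter, and it is modest: a 2.3-fold lower number from compound 1 to compound 2 (0.36 log units; beyond the scatter). The other two stay within it. In this assay, no step beyond the scatter is therefore expected, and the data give no firm direction. The estimated step is small, a 1.3-fold lower number from compound 3 to compound 4 (0.10 log units; within the scatter). For compound 4 the expected value is 2200 nM, with an estimated range of 950 nM to 5000 nM.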

Compound 4, half-maximal inhibitory concentration: 1740 nM
Estimate against measurement, compound 4: 1.3-fold (0.10 log units) above, within the range that was stated.
By their numbers in this assay, from the lowest: compounds 2, 4, 3 and 1 (each within the scatter of the next, the first and the last beyond it).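

In this assay, methoxy on an aromatic carbon, para to a large group, does not separate from either halogen at this position (a 1.6-fold lower number from compound 3 to compound 4 (0.20 log units; within the scatter); a 1.1-fold higher number from compound 2 to compound 4 (0.04 log units; within the scatter)). Against hydrogen at the same place, methoxy gives a second step beyond the scatter, though a modest one (a 2.1-fold lower number from compound 1 to compound 4 (0.32 log units; beyond the scatter)), so both methoxy and fluoro now stand apart from hydrogen. Compound 3 goes against any general rule that substitution here lowers the number, since its step stays within the scatter (a 1.3-fold lower number from compound 1 to compound 3 (0.12 log units; within the scatter)).

Nothing measured here accounts for these numbers. From the compounds shown here alone, whether an amine or a carboxylic acid at this position would give a step beyond the scatter from compound 2 or compound 4 remains open.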